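The source may report more compounds than this note shows. Statements on the series, on what has been measured and on what is new or still open speak of the compounds shown alone.

In a functional assay on SK-OV-3 cells (Homo sapiens) (a lower number here means a stronger inhibitor of growth, a higher number a weaker inhibitor of growth), compound 1 `O=S(=O)(/C=C/c1ccccc1)Cc1ccc(Nc2ncnc3ccccc23)cc1` gives 5000 nM and compound 3 `CC(C)(C)c1cc(/C=C/S(=O)(=O)Cc2ccc(Nc3ncnc4ccccc34)cc2)cc(C(C)(C)C)c1O` gives 3000 nM. Compound 2 `N#Cc1ccc(/C=C/S(=O)(=O)Cc2ccc(Nc3ncnc4ccccc34)cc2)cc1` gives > 100000 nM, which is a limit and not a number; this is the limit of > 100000 nM in this assay, at which 1 of the 3 values shown sits.

Compound 4 `O=S(=O)(/C=C/c1ccc(Cl)cc1)Cc1ccc(Nc2ncnc3ccccc23)cc1` has chloro in place of cyano on an aromatic carbon, para to a large group (chloro in place of cyano on an aromatic carbon). Among the compounds with values here, the only measured step involving this cyano is an at least 20-fold higher number from compound 1 to compound 2 (1.30 log units; beyond the scatter), which is large and beyond the scatter, and it came with cyano in place of hydrogen. With the cyano gone, compound 4 is expected to sit closer to compound 1 at 5000 nM, although chloro is not hydrogen. A large move to a lower number is therefore expected, an estimated at least 16-fold lower number from compound 2 to compound 4 (1.22 log units; beyond the scatter). For compound 4 the estimated value is 6000 nM, with an expected range of 1500 nM to 40000 nM.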

Compound 4, concentration for 50% growth inhibition: 54000 nM
Compound 4: the middle estimate sits 9.0-fold (0.95 log units) below what was measured; measured number outside the range, above it.
By their numbers in this assay, from the lowest: compounds 3 and 1 (each within the scatter of the next); then compound 4. At a limit, above all of these: compound 2.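

In this assay, chloro in place of hydrogen on this aromatic carbon also gives a weaker inhibitor, with an 11-fold higher number from compound 1 to compound 4 (1.03 log units; beyond the scatter), so the loss seen with cyano is not confined to that one group. Compound 2 carries a limit and not a number: the limit of > 100000 nM in this assay, at which 1 of the 4 values shown sits. How chloro compares with cyano stays unsettled, with an at least 1.8-fold lower number from compound 2 to compound 4 (0.26 log units; that floor lies within the scatter), a floor that lies within the scatter.

From the compounds shown here alone, it remains open whether an amine or a carboxylic acid on this aromatic carbon would stay closer to compound 1 at 5000 nM.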